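Chloro on the triazole-linked phenyl of the sulfonamide series

The source may report more compounds than this note shows. Statements on the series, on what has been measured and on what is new or still open speak of the compounds shown alone.

Measured so far:
compound 1 `O=c1[nH]cc(S(=O)(=O)Nc2cccc(-c3cn(-c4ccc(Cl)cc4)nn3)c2)c(=O)[nH]1` — 1730 nM
compound 2 `O=c1[nH]cc(S(=O)(=O)Nc2ccc(-c3cn(-c4ccccc4)nn3)cc2)c(=O)[nH]1` — 7170 nM

In a functional assay on A549 cells (Homo sapiens) for antiproliferative activity, read by MTT assay, with a stated time of 24 h (on this read-out lower numbers stand for stronger inhibition and higher numbers for weaker inhibition), compound 2 gives 7170 nM, the higher of the two numbers recorded for this pair. Compound 1 gives 1730 nM in this assay; the gap between the two lies beyond the usual scatter, but compound 1 differs from compound 2 in more than one place, so no single-change step can be read from it.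

Compound 3 `O=c1[nH]cc(S(=O)(=O)Nc2ccc(-c3cn(-c4cccc(Cl)c4)nn3)cc2)c(=O)[nH]1` has not yet been measured. It differs from compound 2 by chloro in place of hydrogen on an aromatic carbon. Going by the values given here, no step between measured compounds isolates this change; compound 1 carries a chloro group, yet its other difference from compound 2 prevents any attribution. Against that background a step of modest size toward a lower number in this assay is expected for compound 3, not clearly beyond the scatter, reflected in the estimated step of a 1.9-fold lower number from compound 2 to compound 3 (0.28 log units; within the scatter). Compound 3 is accordingly expected to give about 3800 nM in this assay, with a range from 1300 nM to 11000 nM.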

Compound 3, half-maximal inhibitory concentration: 2310 nM
The estimate for compound 3 lay 1.6-fold (0.22 log units) above the measured number; low and high end bracket the measured number.
By their numbers in this assay, from the lowest: compounds 1 and 3 (each within the scatter of the next); then compound 2.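

In this assay, going by these compounds alone, the change from phenyl to 3-chlorophenyl gives a 3.1-fold lower number from compound 2 to compound 3 (0.49 log units; beyond the scatter) and is the only single-change step available so far, with a size beyond the scatter. Chloro in place of hydrogen on this aromatic carbon, meta to a large group, therefore goes with a lower number and is not merely tolerated, which could not be read from compound 1, as steps linking compound 1 to compound 2 or compound 3 cannot be read given their differences in more than one place. Within the data shown here, nothing measured so far bears on why the number moves with this change.

As far as these compounds go, the result covers one group at one carbon, so it remains open whether a methoxy group, an amine or a carboxylic acid at the same carbon would shift the number in the same direction, and whether chloro at other carbons of that phenyl ring would match this step. From the compounds shown here alone, whether the step carries over to the arrangement found in compound 1 also stays open.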